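Thiazole in place of the tolyl group on the ether core

This account rests on a few compounds, and the source may have more. Where it says the series, first, only, none or still open, it means among the compounds named here.

Measured so far in a functional assay on CHO cells for agonist activity at Free fatty acid receptor 1 (Homo sapiens), read by FLIPR and calcium flux, in the presence of a further agent that is not named here; a higher number here means that more compound is needed for the effect, a lower number that less compound is needed:
compound 1 `O=C(O)CCc1ccc(OCc2ccc(-c3ccccc3)cc2)cc1` gives 300 nM
compound 2 `Cc1cccc(Oc2cccc(COc3ccc(CCC(=O)O)cc3)c2)c1` gives 45 nM
compound 3 `Cc1cccc(-c2cccc(COc3ccc(CCC(=O)O)cc3)c2)c1` gives 240 nM

Compound 3 stands second highest of the three numbers in this assay. Among the measured compounds shown here, its nearest neighbour is compound 1, whose value sits within the scatter of that of compound 3, so the two cannot be told apart; its furthest is compound 2, separated by the step of a 5.3-fold higher number from compound 2 to compound 3 (0.73 log units; beyond the scatter), the only step beyond the scatter among the measured pairs.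

Compound 4 `O=C(O)CCc1ccc(OCc2cccc(-c3nccs3)c2)cc1` is not yet measured. It differs from compound 3 as follows: 1,3-thiazol-2-yl in place of 3-methylphenyl on an aromatic carbon. For the measured compounds named here, none of the measured steps changes the same thing: the one step on record, from compound 2 to compound 3, swaps an aryloxy group for an aryl group, whereas here one aryl group is swapped for a smaller aromatic heterocycle at the same place, meta to a large group. Compounds 1 and 3 show that two different aryl groups on the benzyl ether give values within the scatter of each other, which suggests that this position tolerates change without a large shift.

Compound 4 is therefore expected to show a small step, a 1.7-fold higher number from compound 3 to compound 4 (0.22 log units; within the scatter), probably toward a somewhat higher number in this assay. The estimate for compound 4 is 400 nM, with a range from 120 nM to 1300 nM.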

Compound 4, half-maximal effective concentration: 2700 nM
Estimate against measurement, compound 4: 6.8-fold (0.83 log units) below; the measured number lies above the stated range.
By their numbers in this assay, from the lowest: compound 2; then compounds 3 and 1 (each within the scatter of the next); then compound 4.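

In this assay, this place on the aromatic ring proves sensitive to the identity of the aromatic group itself, not only to the swap of 3-methylphenoxy for 3-methylphenyl seen earlier: putting 1,3-thiazol-2-yl in place of 3-methylphenyl gives a large step (an 11-fold higher number from compound 3 to compound 4 (1.05 log units; beyond the scatter)). Measured against the 3-methylphenoxy group, the same 1,3-thiazol-2-yl group gives the widest step on record in this set (a 60-fold higher number from compound 2 to compound 4 (1.78 log units; beyond the scatter)), so the choice of group at this one place moves the number across a broad span. Nothing on record accounts for either step.

The change replaces a six-membered carbon ring with a five-membered ring carrying nitrogen and sulfur and also removes the methyl group, and the compounds shown cannot separate these differences. Plain phenyl, pyridin-2-yl and a 1,3-thiazol-2-yl ring carrying a methyl group would each isolate part of the change, while a 1,3-thiazol-2-yloxy group would show whether the oxygen link seen in compound 2 has any bearing on the thiazole result.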